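The source may report more compounds than this note shows. Statements on the series, on what has been measured and on what is new or still open speak of the compounds shown alone.

Working notes on the series. In a functional assay on the whole organism for inhibition, with Rattus norvegicus as the target, at a dose of 30 mg/kg by the oral route (on this read-out higher numbers stand for more inhibition at the one dose given (going by the name of the read-out) and lower numbers for less inhibition), compound 1 `CN(C(=O)NCCCOc1ccc2nc(O)ccc2c1)C1CCCCC1` gives 15% and is the top of the two numbers measured, but only nominally: compound 2 `CN(C(=O)NCCCOc1ccc2nc(O)ccc2c1)[C@@H]1CCCC[C@H]1O` gives 10%, and the step of a number 5 percentage points lower from compound 1 to compound 2 (within the scatter) is within the scatter. Compound 3 `CCN(CCCOc1ccc2nc(O)ccc2c1)C(=O)N(C)C1CCCCC1` differs from compound 1 by ethyl in place of hydrogen on an amide-type nitrogen. Within the data shown here, no measured step touches the amide-type nitrogen; the one step known, hydroxy in place of hydrogen on a saturated ring carbon, stayed within the scatter. For compound 3 the change is therefore expected to give no step beyond the scatter, no change at the digits printed from compound 1 to compound 3 (within the scatter). Compound 3 is estimated at 15%, range 2% to 32%.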

Compound 3, a percentage reported as inhibition, in the whole organism at one dose (the size of the read-out at that dose, not a potency): 12%
Compound 3: the middle estimate sits 3 percentage points above what was measured; measured number inside the range.
By their numbers in this assay, from the lowest: compounds 2, 3 and 1 (each within the scatter of the next).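

In this assay, ethyl in place of hydrogen on the amide-type nitrogen gives a number 3 percentage points lower from compound 1 to compound 3 (within the scatter) and so shows that this position, which the earlier step did not touch, takes ethyl with no step beyond the scatter. Both changes from compound 1 now stay within the scatter. No measurement on hand bears on this result.

Still open, from the compounds shown here alone, is whether a longer chain or a carboxylic acid on this nitrogen would give a step beyond the scatter. Going by these compounds, whether any change at this position would raise the number at this dose also stays open.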